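Removing one chloro from compound 2

The compounds below may be only part of what the source reports. "The series", "measured", "known", "first", "only" and "open" are said of these compounds alone.

In an ADME assay on K562 cells (Homo sapiens) for antiproliferative activity (on this read-out higher numbers stand for weaker inhibition and lower numbers for stronger inhibition), compound 1 `COc1ccc2nccc(CC[C@H]3CC[C@H](NCc4ccc(Cl)c(Cl)c4)CC3)c2c1` gives "not determined" (no result reported), so it offers no number. Compound 2 `COc1ccc2nccc(CC[C@H]3OC[C@H](NCc4ccc(Cl)c(Cl)c4)CO3)c2c1`, at 20000 nM, holds the higher of the two numbers, and compound 3 `COc1ccc2nccc(CC[C@H]3OC[C@H](NCc4ccc5c(c4)OCCO5)CO3)c2c1` gives 7400 nM. Compound 4 `COc1ccc2nccc(CC[C@H]3OC[C@H](NCc4ccc(Cl)cc4)CO3)c2c1` is still unmeasured. It differs from compound 2 by hydrogen in place of chloro on an aromatic carbon, ortho to a chloro group. Going by the values given here, the only measured step that bears on this is a 2.7-fold lower number from compound 2 to compound 3 (0.43 log units; beyond the scatter). That step replaces the whole 3,4-dichlorophenyl group, so it is a loose guide. A small shift to a lower number in this assay is expected, possibly within the scatter. The expected step is a 1.3-fold lower number from compound 2 to compound 4 (0.12 log units; within the scatter). For compound 4 the estimated value is 15000 nM, with an expected range of 7000 nM to 30000 nM.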

Compound 4, half-maximal inhibitory concentration: 12000 nM
For compound 4 the middle estimate is 1.3-fold (0.10 log units) above the measured one; low and high end bracket the measured number.
By their numbers in this assay, from the lowest: compounds 3, 4 and 2 (each within the scatter of the next, the first and the last beyond it).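

In this assay, hydrogen in place of the chloro ortho to a chloro group gives a 1.7-fold lower number from compound 2 to compound 4 (0.22 log units; within the scatter), so at this position the change from 3,4-dichlorophenyl to 4-chlorophenyl is not resolved from the scatter. The other step to compound 4, a 1.6-fold higher number from compound 3 to compound 4 (0.21 log units; within the scatter), likewise does not separate 4-chlorophenyl from 2,3-dihydro-1,4-benzodioxin-6-yl, which places compound 4 within the scatter of both compound 2 and compound 3. No measurement at hand accounts for these numbers. Open, on these data alone, is whether an unsubstituted benzyl group stays in this range. Also open, as far as these compounds go, is how a methoxy group or a fluoro group would read in place of the remaining chloro.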